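A few compounds are considered here, and "the series" means these few. Any claim that something is new, unique, unknown or untested is made for them only; others in the source may bear on it.

Working notes on the series.

The three measured compounds share one core and are compared in a functional assay (HSMC cells, Homo sapiens) for antiproliferative activity, with a stated time of 72 h; a lower number here means a stronger inhibitor, a higher number a weaker inhibitor. Compound 1 `COC(=O)[C@H](CCSC)NC(=O)c1ccc(C(=O)NC[C@@H]2COc3ccccc3O2)cc1-c1ccccc1C` gives 533000 nM. Compound 2 `COC(=O)CNC(=O)c1ccc(C(=O)NC[C@@H]2COc3ccccc3O2)cc1-c1ccccc1C` gives 89000 nM. Compound 3 `COC(=O)[C@H](CC(C)C)NC(=O)c1ccc(C(=O)NC[C@H]2COc3ccccc3O2)cc1-c1ccccc1C` gives 103000 nM, which is the second highest of the three numbers; its nearest neighbour is compound 2, within the scatter, and its furthest is compound 1, beyond the scatter. Among the compounds with values here, the one measured step, a 6.0-fold lower number from compound 1 to compound 2 (0.78 log units; beyond the scatter), concerns the side chain on the saturated carbon bound to the amide-type nitrogen and the carbonyl carbon, and is modest.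

Compound 4 `COC(=O)[C@H](CC(C)C)NC(=O)c1ccc(C(=O)NC[C@@H]2COc3ccccc3O2)cc1-c1ccccc1C` is not yet measured. It differs from compound 3 only in configuration: the two compounds have the same atoms and bonds and differ only in configuration as drawn: 1 of 2 stereo elements differ; a stereocentre at a saturated ring carbon is drawn S in compound 3 and R in compound 4. Within the data shown here, no measured pair differs solely at this ring stereocentre, so no step in hand bears on the change; compounds 1 and 2 carry the drawn configuration of compound 4, but each also differs from compound 3 in the side chain, so their values say nothing direct about the inversion alone.

With no guidance beyond the scatter, the number for compound 4 is expected to sit close to compound 3, and the expected step of a 1.0-fold lower number from compound 3 to compound 4 (0.01 log units; within the scatter) is essentially none, with wide uncertainty. The estimate for compound 4 in this assay is therefore 100000 nM, in the range 30000 nM to 350000 nM.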

Compound 4, half-maximal inhibitory concentration: 88000 nM
Compound 4: the middle estimate sits 1.1-fold (0.06 log units) above what was measured; measured number inside the range.
By their numbers in this assay, from the lowest: compounds 4, 2 and 3 (each within the scatter of the next); then compound 1.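

In this assay, the pair compound 3 and compound 4 isolates the ring stereocentre, and inverting it from S to R gives a 1.2-fold lower number from compound 3 to compound 4 (0.07 log units; within the scatter), so at this position, with the isobutyl side chain, the drawn configuration does not separate the two numbers: the fact that compounds 3 and 4 differ only in the configuration as drawn With the R ring configuration held, isobutyl in place of hydrogen on the saturated chain carbon gives a 1.0-fold lower number from compound 2 to compound 4 (0.00 log units; within the scatter), which shows that this side chain and hydrogen are not separated here. Isopropyl in place of (methylsulfanyl)methyl gives a 6.1-fold lower number from compound 1 to compound 4 (0.78 log units; beyond the scatter), a step of about the same size as a 6.0-fold lower number from compound 1 to compound 2 (0.78 log units; beyond the scatter), so among compounds 1, 2 and 4 only the 2-(methylsulfanyl)ethyl side chain of compound 1 stands apart.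

Within the data shown here, whether the ring stereocentre is equally silent with the hydrogen or 2-(methylsulfanyl)ethyl side chains stays open, as the only pair that isolates it carries isobutyl. Also open, going by these compounds, is how this assay responds to a carboxylic acid in place of the methyl ester, or to an amine on the side chain.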